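A Ring Swap Tested on a Second Core

The source may hold more compounds than are shown below. What is called first, only, known or untested is meant among the compounds shown, and "the series" means these compounds.

Compound 1, `COc1ccc(C[C@H]2CC[C@](O)(CC(=O)Nc3ccc4[nH]c(=O)oc4c3)CC2)cc1`, and compound 2, `O=C(C[C@]1(O)CC[C@@H](Cc2ccc(F)c(F)c2)CC1)Nc1ccc2[nH]c(=O)oc2c1`, share one core and differ in a single place: 3,4-difluorophenyl in place of 4-methoxyphenyl on a saturated chain carbon bound to a saturated ring carbon. In an ADME assay on the whole organism (strain Sprague-Dawley) for pharmacokinetics, with Rattus norvegicus as the target, using cassette dosing (a lower number here means slower removal, a higher number faster removal of the compound), compound 1 gives 45.9 mL/min/kg, and compound 2 gives 35.7 mL/min/kg, so that a 1.3-fold lower number from compound 1 to compound 2 (0.11 log units; within the scatter). Compound 3, `COc1ccc(C[C@H]2CC[C@](O)(Cc3cc(-c4cn[nH]c4)on3)CC2)cc1`, is built on a different core; how its core differs from that of compound 1 is not broken down here. In this assay compound 3 gives 61.8 mL/min/kg, and both compound 1 and compound 2 sit within the scatter of that number. Compound 4, `O[C@]1(Cc2cc(-c3cn[nH]c3)on2)CC[C@H](Cc2ccc(F)c(F)c2)CC1`, is compound 3 carrying the same change already seen between compound 1 and compound 2: 3,4-difluorophenyl in place of 4-methoxyphenyl on a saturated chain carbon bound to a saturated ring carbon. Since this change has so far been made only once, the expectation for compound 4 rests on that single pair. Because a 1.3-fold lower number from compound 1 to compound 2 (0.11 log units; within the scatter) stayed within the scatter, the new step is expected to be small as well, and a 1.2-fold lower number from compound 3 to compound 4 (0.09 log units; within the scatter) is the estimated size of it in this assay. Compound 4 is therefore expected to give 50 mL/min/kg, most likely between 28 mL/min/kg and 90 mL/min/kg.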

Compound 4, clearance: 15.2 mL/min/kg
For compound 4 the middle estimate is 3.3-fold (0.52 log units) above the measured one; the whole stated range lies above it.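

In this assay, the same swap of 4-methoxyphenyl for 3,4-difluorophenyl on the core of compound 3 gives a 4.1-fold lower number from compound 3 to compound 4 (0.61 log units; beyond the scatter), and it does not match the step seen on the core of compound 1: the same change on two cores in this assay, a 1.3-fold lower number (0.11 log units; within the scatter) from compound 1 to compound 2 and a 4.1-fold lower number (0.61 log units; beyond the scatter) from compound 3 to compound 4, 3.2-fold (0.50 log units) apart, beyond the scatter of two such steps Only on the core of compound 3 does the change clear the scatter, so the size of the step seen on one core did not carry over to the other. With just these two pairs, the result shows that the size of the step differs with the core in these compounds, but it does not show which part of the cores accounts for the gap or what the change would do on a third core.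

The compounds shown leave open whether another group at this place, such as an unsubstituted benzyl or a chlorobenzyl, would also give steps that differ between the two cores. They also leave open whether the larger step would survive on the core of compound 3 with an amine in place of the hydroxyl.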